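Aryl amide substituent series: chloro to methoxy

This account rests on a few compounds, and the source may have more. Where it says the series, first, only, none or still open, it means among the compounds named here.

Measured so far:
compound 1, `CC(C)[C@@H]1CC[C@@H](C)C[C@@]12N(C)C(=O)[C@@H]1[C@H]3C(=O)N(C)C(=O)[C@H]3ON12`, a functional assay, read by spectrophotometry, with a stated time of 2 h, tested at 2 mg/mL (on this read-out higher numbers stand for a stronger effect at the one concentration tested and lower numbers for a weaker effect), 59.9%
compound 2, `CC(C)[C@@H]1CC[C@@H](C)C[C@@]12N(C)C(=O)[C@@H]1[C@H]3C(=O)N(c4ccc(Cl)cc4)C(=O)[C@H]3ON12`, this assay 49.4%

Going by the values given here, compound 2 stands lowest of the two numbers available, with compound 1 as its only neighbour; the one measured step, a number 10.5 percentage points lower from compound 1 to compound 2 (beyond the scatter), lies beyond the scatter and puts compound 2 the weaker of the pair.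

Compound 3, `COc1ccc(N2C(=O)[C@H]3[C@H](ON4[C@@H]3C(=O)N(C)[C@@]43C[C@H](C)CC[C@H]3C(C)C)C2=O)cc1`, is the next member. It differs from compound 2 in one place: methoxy in place of chloro on an aromatic carbon. Among the compounds with values here, no measured step bears on this change. Within the data shown here, the single step available, from methyl to 4-chlorophenyl on the ring nitrogen, concerns a different position and a different kind of exchange, and it says nothing about swapping one para group of the aromatic ring for another. With nothing to suggest a direction, the expectation is that compound 3 stays close to where it starts and that the estimated step of a number 0.6 percentage points higher from compound 2 to compound 3 (within the scatter) falls within the scatter.

Compound 3 is therefore estimated at 50%, within a range from 35% to 65%.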

Compound 3, a percentage reported as activity, at one concentration (the size of the read-out at that concentration, not a potency): 68.9%
Estimate against measurement, compound 3: 18.9 percentage points below; measured number outside the range, above it.
By their numbers in this assay, from the lowest: compound 2; then compounds 1 and 3 (each within the scatter of the next).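

Methoxy in place of chloro on the aromatic carbon para to a large group gives a number 19.5 percentage points higher from compound 2 to compound 3 (beyond the scatter) in this assay, so the read-out responds to the group at this place on the ring, which the exchange on the ring nitrogen alone could not show. The lower number seen with 4-chlorophenyl therefore does not go with an aromatic ring on the amide-type nitrogen as such: 4-methoxyphenyl in place of methyl gives a number 9 percentage points higher from compound 1 to compound 3 (within the scatter), and these two compounds cannot be told apart in this read-out. No available data explain the difference between chloro and methoxy at this place.

Going by these compounds alone, with only two groups at this place, it remains open how a plain hydrogen, a fluoro, a dimethylamino group, a carboxylic acid or a longer chain such as butoxy would read, and so whether chloro or methoxy is the exception. Each number also comes from one concentration, so the series gives the size of the effect at that concentration and leaves potency open.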